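This account rests on a few compounds, and the source may have more. Where it says the series, first, only, none or still open, it means among the compounds named here.

Measured in a functional assay for inhibition, with Rattus norvegicus as the target; a lower number here means a stronger inhibitor, a higher number a weaker inhibitor:
Compound 1 `Cc1c(C)c2c(c(C)c1O)CCC(C)(/C=[N+](\[O-])C(C)(C)C)O2`: 6800000 nM
Compound 2 `COc1c(C)c(C)c2c(c1C)CCC(C)(/C=[N+](\[O-])C(C)(C)C)O2`: 22000000 nM
Compound 3 `Cc1c(C)c2c(c(C)c1O)CCC(C)(/C=[N+](\[O-])C1CC1)O2`: 12000000 nM

Compound 3 lies within the usual scatter of each of the other two compounds, although those two are separated by a larger gap. Compound 4 `COc1c(C)c(C)c2c(c1C)CCC(C)(/C=[N+](\[O-])C1CC1)O2` differs from compound 3 by methyl in place of hydrogen on an oxygen on an aromatic ring, a methyl in place of hydrogen on an oxygen on an aromatic ring, or hydroxy to methoxy. Going by the values given here, only one measured step makes this same change, a 3.2-fold higher number from compound 1 to compound 2 (0.51 log units; beyond the scatter). The other, a 1.8-fold higher number from compound 1 to compound 3 (0.25 log units; within the scatter), concerns a different place and serves only to link the two series. A modest rise in the number is therefore expected in this assay. The expected step is a 3.2-fold higher number from compound 3 to compound 4 (0.50 log units; beyond the scatter). Compound 4 is estimated at 38000000 nM, with an expected range of 18000000 nM to 80000000 nM.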

Compound 4, half-maximal inhibitory concentration: 11000000 nM
Compound 4: middle estimate off by 3.5-fold (0.54 log units), on the high side, outside the stated range (below it).
By their numbers in this assay, from the lowest: compounds 1, 4, 3 and 2 (each within the scatter of the next, the first and the last beyond it).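

In this assay, hydroxy to methoxy with cyclopropyl on the double-bonded nitrogen gives a 1.1-fold lower number from compound 3 to compound 4 (0.04 log units; within the scatter), so the rise seen with tert-butyl there does not carry over: the same change on two cores in this assay, a 3.2-fold higher number (0.51 log units; beyond the scatter) from compound 1 to compound 2 and a 1.1-fold lower number (0.04 log units; within the scatter) from compound 3 to compound 4, 3.5-fold (0.55 log units) apart, beyond the scatter of two such steps. Read the other way, with methoxy in place, cyclopropyl in place of tert-butyl gives a 2.0-fold lower number from compound 2 to compound 4 (0.30 log units; within the scatter), and the size of this change also depends on its partner: the same change on two cores in this assay, a 1.8-fold higher number (0.25 log units; within the scatter) from compound 1 to compound 3 and a 2.0-fold lower number (0.30 log units; within the scatter) from compound 2 to compound 4, 3.5-fold (0.55 log units) apart, beyond the scatter of two such steps. The two changes therefore do not simply add across these compounds. The compounds shown leave open whether this holds for other groups on that nitrogen, such as phenyl or a longer chain. They also leave open how an ethoxy on the aromatic ring would compare.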